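Methoxy for Fluoro on a Series at the Assay Limit

The source may hold more compounds than are shown below. What is called first, only, known or untested is meant among the compounds shown, and "the series" means these compounds.

Compound 1, `CC(C)n1ncc2c(C(=O)NCc3cn(-c4ccc(I)cc4)nn3)cccc21`, gives in a functional assay on MCF7 cells (Homo sapiens) for inhibition, read by MTT assay, with a stated time of 72 h (on this read-out lower numbers stand for stronger inhibition and higher numbers for weaker inhibition), the limit > 40000 nM.
Compound 2, `CC(C)n1ncc2c(C(=O)NCc3cn(-c4ccc(F)cc4)nn3)cccc21`, gives in this assay the limit > 40000 nM.
Compound 3, `Cc1cccc(-n2cc(CNC(=O)c3cccc4c3cnn4C(C)C)nn2)c1`, gives in this assay the limit > 40000 nM.

Compound 2 therefore stands at the limit, the same place as every other value shown, (the limit of > 40000 nM in this assay, at which 3 of the 3 values shown sit). Because all sit at that limit, the steps a step that the two limits leave unreadable from compound 1 to compound 2, a step that the two limits leave unreadable from compound 2 to compound 3 and a step that the two limits leave unreadable from compound 1 to compound 3 have no readable size. Compound 4, `COc1ccc(-n2cc(CNC(=O)c3cccc4c3cnn4C(C)C)nn2)cc1`, differs from compound 2 by methoxy in place of fluoro on an aromatic carbon. Among the measured compounds shown here, no measured step with a readable size bears on this change, so nothing points to a gain or a loss in this assay beyond the limit itself. Compound 4 is estimated at 50000 nM, with a range of 15000 nM to 150000 nM, most likely again reported as a limit, an expected step that the limit leaves unreadable from compound 2 to compound 4.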

Compound 4, half-maximal inhibitory concentration: > 40000 nM
Compound 4 ended at the assay's limit; the forecaster's own chance of this, stated with the estimate: 80%; the middle value does not contradict the limit.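

No step can be read among compound 1, compound 2, compound 3 and compound 4, because all four rest at one assay limit: the limit of > 40000 nM in this assay, at which 4 of the 4 values shown sit.

As far as these compounds go, whether these group changes alter inhibition in this assay stays open, as the true strength of each compound is unknown.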